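The compounds below may be only part of what the source reports. "The series", "measured", "known", "first", "only" and "open" are said of these compounds alone.

In a functional assay on CCRF-CEM cells (Homo sapiens) (a lower number here means a stronger inhibitor, a higher number a weaker inhibitor), three compounds have been measured so far. Compound 1, with structure `CCC1(C)OC(/C(C)=C/COc2ccc3ccc(=O)oc3c2)=CC1=N`, gives 3.57 ug/mL in this assay. Compound 2, with structure `C/C(=C\CO)CC1=CC(=O)C(C)(C)O1`, gives 10.3 ug/mL in this assay. Compound 3, with structure `COc1ccccc1C1=CC(=O)CO1`, shares none of the side chains of the first two and carries a single aromatic ring on its core. For compound 3 the assay reports only a limit, > 100 ug/mL, and no number. Compound 3 thus stands at the edge of what this assay can report, the same edge described by the limit of > 100 ug/mL in this assay, at which 1 of the 3 values shown sits, and among the three measured compounds it is the one for which no finite value is known.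

Compound 4, with structure `O=C1C=C(c2ccccc2)OC1`, has not yet been measured in this assay. It differs from compound 3 in one place: hydrogen in place of methoxy on an aromatic carbon. For the measured compounds named here, no step between measured compounds involves this change, so its size in this assay is unknown. With compound 3 already at a limit, no step beyond the usual scatter in either direction is expected for this change; the expected step of a number no higher from compound 3 to compound 4 (the limit leaves the size open) is essentially flat. Compound 4 is therefore expected to give about 100 ug/mL in this assay, with a range from 30 ug/mL to 300 ug/mL, and most likely again only a limit.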

Compound 4, concentration for 50% inhibition: 30.2 ug/mL
Beside the measured number, compound 4's estimate is 3.3-fold (0.52 log units) above it, and the stated range covers the measured number.
By their numbers in this assay, from the lowest: compound 1; then compound 2; then compound 4. At a limit, above all of these: compound 3.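

In this assay, for the compounds shown here, this pair gives the first reading of a change at this aromatic carbon, where hydrogen in place of methoxy gives an at least 3.3-fold lower number from compound 3 to compound 4 (0.51 log units; beyond the scatter). The size of that step is only a lower bound, since compound 3 stands at a limit of the assay: the limit of > 100 ug/mL in this assay, at which 1 of the 4 values shown sits. Going by these compounds alone, compound 4 also shows that this core, with no group at this place on the ring, gives a finite number in this assay, which the earlier compounds could not show, as no two of them differed in one place.

On these data alone, what remains open is whether the step belongs to methoxy in particular, since this one pair cannot say whether fluorine, a hydroxyl or an amine on the same aromatic carbon would stay near compound 4 or return to a limit. Within the data shown here, it also leaves open whether methoxy on another carbon of that ring would behave the same way, and compound 4 differs from compound 1 and compound 2 in more than one place, so no step to either can be read.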